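A few compounds are considered here, and "the series" means these few. Any claim that something is new, unique, unknown or untested is made for them only; others in the source may bear on it.

Compound 1 `CC(C)c1n[nH]c2c(NCc3ccc(-c4ccccn4)cc3)nc(SCC(O)CN3CCNCC3)nc12`: 332 nM
Compound 2 `CC(C)c1n[nH]c2c(NCc3ccc(-c4ccccn4)cc3)nc(SCCN)nc12`: 22 nM
Compound 3 `CC(C)c1n[nH]c2c(NCc3ccc(-c4ccccn4)cc3)nc(SCCCO)nc12`: 109 nM

In a functional assay on HT cells (Homo sapiens) for antiproliferative activity, read by fluorescence, with a stated time of 72 h (a lower number here means a stronger inhibitor of growth, a higher number a weaker inhibitor of growth), compound 3 stands second highest of the three numbers: compound 1 gives a higher number, a 3.0-fold lower number from compound 1 to compound 3 (0.48 log units; beyond the scatter), and compound 2 a lower one, a 5.0-fold higher number from compound 2 to compound 3 (0.70 log units; beyond the scatter). Compound 4 `CC(C)c1n[nH]c2c(NCc3ccc(-c4ccccn4)cc3)nc(SC[C@H](O)CN)nc12` differs from compound 3 in one place: 2-amino-1-hydroxyethyl in place of 2-hydroxyethyl on a saturated chain carbon bound to a sulfur. The step bearing most on this is a 5.0-fold higher number from compound 2 to compound 3 (0.70 log units; beyond the scatter), where amino gave way to hydroxymethyl and the number rose; compound 4 brings an amino group back while keeping the hydroxyl. The step of a 3.0-fold lower number from compound 1 to compound 3 (0.48 log units; beyond the scatter) shows that 1-hydroxy-2-(piperazin-1-yl)ethyl gives a higher number than 2-hydroxyethyl. A modest lower number is therefore expected, a 2.4-fold lower number from compound 3 to compound 4 (0.38 log units; beyond the scatter), smaller than the gain seen with compound 2. Compound 4 is estimated at 45 nM in this assay, within 15 nM to 130 nM.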

Compound 4, concentration for 50% growth inhibition: 63 nM
Beside the measured number, compound 4's estimate is 1.4-fold (0.15 log units) below it; the measured number falls inside the stated range.
By their numbers in this assay, from the lowest: compound 2; then compounds 4 and 3 (each within the scatter of the next); then compound 1.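

In this assay, the 2-amino-1-hydroxyethyl group in place of 2-hydroxyethyl on this saturated chain carbon bound to a sulfur leaves compound 4 within the scatter of compound 3, at a 1.7-fold lower number from compound 3 to compound 4 (0.24 log units; within the scatter). The same group does not match aminomethyl, with a 2.9-fold higher number from compound 2 to compound 4 (0.46 log units; beyond the scatter). It does outperform 1-hydroxy-2-(piperazin-1-yl)ethyl, with a 5.3-fold lower number from compound 1 to compound 4 (0.72 log units; beyond the scatter). Nothing available here explains these differences. Going by these compounds, how a carboxylic acid or a longer chain carrying an amine would compare at this place remains open, as does the role of the defined stereocentre of compound 4.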